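Ethylsulfonyl for Propylcarbonyl: Expected Permeability of Compound 4

This account rests on a few compounds, and the source may have more. Where it says the series, first, only, none or still open, it means among the compounds named here.

Three compounds have been measured:
compound 1, `Cn1cncc1CN1CC(N(CC2CCN(C(=O)c3ccc(Cl)cc3)CC2)S(=O)(=O)c2ccccn2)Cc2cc(C#N)ccc21`, gives 0.5 10^-6 cm/s in an ADME assay on Caco-2 cells (Homo sapiens) for permeability, in the apical to basolateral direction; a lower number here means that the compound crosses the layer more slowly, a higher number that the compound crosses the layer faster
compound 2, `CCCC(=O)N1CCC(CN(C2Cc3cc(C#N)ccc3N(Cc3cncn3C)C2)S(=O)(=O)c2ccccn2)CC1`, gives 0.5 10^-6 cm/s in this assay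
compound 3, `Cn1cncc1CN1CC(N(CC2CCN(C(=O)N3CCCCC3)CC2)S(=O)(=O)c2ccccn2)Cc2cc(C#N)ccc21`, gives 0.6 10^-6 cm/s in this assay

Compound 2 stands level with compound 1 at the digits shown, and the two together sit at the lowest of the three numbers; the step of no change at the digits printed from compound 1 to compound 2 (within the scatter) and the step of a 1.2-fold higher number from compound 2 to compound 3 (0.08 log units; within the scatter) both stay within the scatter, as does a 1.2-fold higher number from compound 1 to compound 3 (0.08 log units; within the scatter). All three compounds share one core, and the measured steps only exchange the group on the carbonyl carbon: propyl, 4-chlorophenyl, or piperidin-1-yl.

Compound 4, `CCS(=O)(=O)N1CCC(CN(C2Cc3cc(C#N)ccc3N(Cc3cncn3C)C2)S(=O)(=O)c2ccccn2)CC1`, is not yet measured. It differs from compound 2 as follows: ethylsulfonyl in place of propylcarbonyl on an amine nitrogen in a ring. Among the compounds with values here, no measured step exchanges the carbonyl itself for a sulfonyl on this amine nitrogen, so the three steps bear on compound 4 only indirectly: they show that exchanging the group carried on that side of the molecule left this assay unchanged within the scatter in every case. On that basis the step of no change at the digits printed from compound 2 to compound 4 (within the scatter) is expected to stay within the scatter, with no direction favoured. Compound 4 is therefore estimated at 0.5 10^-6 cm/s, with a range from 0.25 10^-6 cm/s to 1 10^-6 cm/s.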

Compound 4, apparent permeability: 0.1 10^-6 cm/s
Beside the measured number, compound 4's estimate is 5.0-fold (0.70 log units) above it; the measured number lies below the stated range.
By their numbers in this assay, from the lowest: compound 4; then compounds 1, 2 and 3 (each within the scatter of the next).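

In this assay, the three carbonyl compounds stayed within the scatter of one another, but replacing the carbonyl-linked group on this amine nitrogen with ethylsulfonyl gives a change beyond the scatter, seen as a 5.0-fold lower number from compound 2 to compound 4 (0.70 log units; beyond the scatter) and as a 6.0-fold lower number from compound 3 to compound 4 (0.78 log units; beyond the scatter) and again as a 5.0-fold lower number from compound 1 to compound 4 (0.70 log units; beyond the scatter), whichever group it replaces: propyl, piperidin-1-yl or 4-chlorophenyl on the carbonyl. Propylcarbonyl and ethylsulfonyl have the same count of heavy atoms, and neither has a ring, a hydrogen-bond donor or a net charge, so these counts do not separate them, whereas the atoms themselves and the hydrogen-bond acceptor count do. Nothing measured here accounts for the lower number.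

Compound 4 is the only sulfonyl compound shown on this nitrogen, and its chain is also shorter than the propyl of compound 2, so it stays open whether propylsulfonyl, 4-chlorophenylsulfonyl or dimethylaminosulfonyl would give a similarly low number. Also open, going by these compounds, is what a free piperidine amine or a simple methyl on that nitrogen would give.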